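Hydroxy to Amino Across Two Antiproliferative Cores

The source may report more compounds than this note shows. Statements on the series, on what has been measured and on what is new or still open speak of the compounds shown alone.

Compound 1 `COc1ccc(C(=O)c2ccc3c(c2)C=CC(C)(C)O3)c(NC(=O)CO)c1` and compound 2 `COc1ccc(C(=O)c2ccc3c(c2)C=CC(C)(C)O3)c(NC(=O)CN)c1` share one core and differ in a single place: amino in place of hydroxy on a saturated chain carbon bound to a carbonyl carbon. In a functional assay on A549 cells (Homo sapiens) for antiproliferative activity, read by MTT assay, with a stated time of 48 h (on this read-out higher numbers stand for weaker inhibition and lower numbers for stronger inhibition), compound 1 gives 90 nM, while compound 2 gives 310 nM, which amounts to a 3.4-fold higher number from compound 1 to compound 2 (0.54 log units; beyond the scatter). Compound 3 `C=C(c1cc(OC)c(OC)c(OC)c1)c1ccc(OC)cc1NC(=O)CO` is built on another core, and the difference between the two cores is not broken down here. In this assay compound 3 gives 20 nM, the lowest of the three numbers. Compound 4 `C=C(c1cc(OC)c(OC)c(OC)c1)c1ccc(OC)cc1NC(=O)CN` has not yet been measured; it differs from compound 3 exactly as compound 2 differs from compound 1: amino in place of hydroxy on a saturated chain carbon bound to a carbonyl carbon. Among the compounds with values here, because the same change at the same place gave a 3.4-fold higher number from compound 1 to compound 2 (0.54 log units; beyond the scatter) as its only precedent, the account expects the step to be of similar size, namely a 3.5-fold higher number from compound 3 to compound 4 (0.54 log units; beyond the scatter), while allowing that a single earlier instance on a different core is a thin basis. Compound 4 is therefore estimated at 70 nM in this assay, with a likely range from 30 nM to 160 nM.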

Compound 4, half-maximal inhibitory concentration: 40 nM
Compound 4: middle estimate off by 1.8-fold (0.24 log units), on the high side; the measured number falls inside the stated range.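

On the core of compound 3, amino in place of hydroxy on a saturated chain carbon bound to a carbonyl carbon gives, in this assay, a 2.0-fold higher number from compound 3 to compound 4 (0.30 log units; within the scatter), so on this core the change cannot be told apart from repeat measurement. Set beside the step on the core of compound 1, the new step does not differ from it by more than such measurements allow: the same change on two cores in this assay, a 3.4-fold higher number (0.54 log units; beyond the scatter) from compound 1 to compound 2 and a 2.0-fold higher number (0.30 log units; within the scatter) from compound 3 to compound 4, 1.7-fold (0.24 log units) apart, within the scatter of two such steps. The change therefore carries from one core to the other without a detectable difference in step size, although the step is beyond the scatter on one core and within it on the other, and two cores cannot show that it would hold on a third.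

The compounds shown leave open how a dimethylamino group or a carboxylic acid at the same place would compare with hydroxy and amino. They also leave open whether a longer chain carrying either group would give steps of the same size.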